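The source may report more compounds than this note shows. Statements on the series, on what has been measured and on what is new or still open speak of the compounds shown alone.

Measured compounds and their values:
- compound 1 `CS(=O)(=O)c1ccc(Cc2nnc3n2N=C(c2ccc(Cl)cc2Cl)CS3)cc1`: 27.3%
- compound 2 `CS(=O)(=O)c1ccc(Cc2nnc3n2N=C(c2cc(Cl)sc2S(N)(=O)=O)CS3)cc1`: 27.5%
- compound 3 `CS(=O)(=O)c1ccc(Cc2nnc3n2N=C(c2cc4ccccc4c(=O)o2)CS3)cc1`: 14.9%

All three share one core and differ only in the group attached to the carbon that carries a double bond to nitrogen. In a functional assay on HT-29 cells (Homo sapiens) for cytotoxicity, read by MTT assay, with a stated time of 48 h, tested at 50 uM (on this read-out higher numbers stand for a stronger effect at the one concentration tested and lower numbers for a weaker effect), compound 1 stands second highest of the three numbers. Its nearest neighbour is compound 2, reached by a number 0.2 percentage points higher from compound 1 to compound 2 (within the scatter), a step that stays within the scatter of repeated measurements. Compound 3 gives the lowest of the three numbers, and its gap to compound 1 lies beyond the scatter.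

Compound 4 `CS(=O)(=O)c1ccc(Cc2nnc3n2N=C(c2cc(Cl)sc2Cl)CS3)cc1` is not yet measured. It differs from compound 1 in one place: 2,5-dichlorothiophen-3-yl in place of 2,4-dichlorophenyl on a carbon with a double bond to nitrogen. Going by the values given here, the only measured step that bears on this is the one from compound 1 to compound 2, where the same 2,4-dichlorophenyl group was likewise replaced by a chlorinated thiophene ring, and the number hardly moved. On that basis the step from compound 1 to compound 4 in this assay is expected to be small, with no clear direction, giving an estimated a number 1.3 percentage points lower from compound 1 to compound 4 (within the scatter). For compound 4 in this assay the estimate is 26%, expected to fall between 14% and 38%.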

Compound 4, a percentage reported as activity, at one concentration (the size of the read-out at that concentration, not a potency): 25.5%
Estimate against measurement, compound 4: 0.5 percentage points above; the measured number falls inside the stated range.
By their numbers in this assay, from the lowest: compound 3; then compounds 4, 1 and 2 (each within the scatter of the next).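

The new compound separates two things that compound 2 had left joined, since compound 2 carried both a five-membered aromatic ring and a sulfamoyl group. In this assay, replacing 2,4-dichlorophenyl with 2,5-dichlorothiophen-3-yl, with no sulfamoyl group present, gives a small step (a number 1.8 percentage points lower from compound 1 to compound 4 (within the scatter)), and exchanging sulfamoyl for chloro on the thiophene ring also gives a small one (a number 2 percentage points lower from compound 2 to compound 4 (within the scatter)), so among compounds 1, 2 and 4 neither the six-membered carbon ring nor the sulfamoyl group is needed to keep the number at this level, while compound 3 goes against this flat picture, with 14.9% in this assay. No measurement in hand explains why these three compounds sit so close together, or why compound 3 gives a lower number.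

The compounds shown leave open whether the chlorines matter at all, as no plain thiophen-3-yl or unsubstituted phenyl appears among them. Also open, on these data alone, is how a ring-free group at this carbon, such as a short alkyl chain, or an amine on the ring would behave, and with a single tested concentration, these numbers say nothing about potency.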